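Benzofuran in place of furan on a limit compound

The source may report more compounds than this note shows. Statements on the series, on what has been measured and on what is new or still open speak of the compounds shown alone.

Measured in an ADME assay on MRC5 cells (Homo sapiens), read by MTT assay, with a stated time of 72 h (a higher number here means a weaker inhibitor, a lower number a stronger inhibitor), as follows:
- compound 1 `COc1ncnc2c1c(-c1cc3ccccc3o1)cn2[C@@H]1O[C@H](CO)[C@@H](O)[C@H]1O` gives (65600 nM)
- compound 2 `CNc1ncnc2c1c(-c1ccoc1)cn2[C@@H]1O[C@H](CO)[C@@H](O)[C@H]1O` gives (> 100000 nM), a limit
- compound 3 `CN(C)c1ncnc2c1c(-c1ccoc1)cn2[C@@H]1O[C@H](CO)[C@@H](O)[C@H]1O` gives (> 100000 nM), a limit

Compound 3 has no number in this assay, only a limit (> 100000 nM). Compound 2 likewise has only a limit (> 100000 nM). Both stand at the same point (the limit of > 100000 nM in this assay, at which 2 of the 3 values shown sit).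

Compound 4 `CN(C)c1ncnc2c1c(-c1cc3ccccc3o1)cn2[C@@H]1O[C@H](CO)[C@@H](O)[C@H]1O` follows from compound 3 by one change (1-benzofuran-2-yl in place of furan-3-yl on an aromatic carbon), with 1-benzofuran-2-yl in place of furan-3-yl on an aromatic carbon. Going by the values given here, the only measured step (a step that the two limits leave unreadable from compound 2 to compound 3) is a change elsewhere and gives no size to carry over. Among the compounds with values here, compound 1 (65600 nM) carries the same 1-benzofuran-2-yl and is the only compound with a number, so a modest move towards stronger inhibition is expected. Another limit remains possible for compound 4. The expected step (an at least 2.0-fold lower number from compound 3 to compound 4 (0.30 log units; that floor lies within the scatter)) is an estimate measured from a limit. Compound 4 is estimated at (50000 nM), with an expected range from (12000 nM) to (100000 nM).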

Compound 4, half-maximal inhibitory concentration: > 100000 nM
Compound 4 ended at the assay's limit (the forecaster's own chance of this, stated with the estimate: 35%); middle value at least 2.0-fold (0.30 log units) from the limit.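

In this assay compound 4 gives > 100000 nM, a limit of the assay, so 1-benzofuran-2-yl on this aromatic carbon does not by itself bring a dimethylamino compound to a measurable number. With 1-benzofuran-2-yl held constant, dimethylamino in place of methoxy gives an at least 1.5-fold higher number from compound 1 to compound 4 (0.18 log units; that floor lies within the scatter), and only this floor is known. The step from furan-3-yl to 1-benzofuran-2-yl cannot be read, like the other step between two limits, and the values stay bunched at one point: the limit of > 100000 nM in this assay, at which 3 of the 4 values shown sit.

Without a methoxy compound carrying furan-3-yl, the shares of methoxy and 1-benzofuran-2-yl in the number for compound 1 cannot be separated. Also open, from the compounds shown here alone, is how an unsubstituted amino group or an ethoxy group in place of methoxy would read against compound 1.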